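Swapping the basic side chain on a ring nitrogen

A few compounds are considered here, and "the series" means these few. Any claim that something is new, unique, unknown or untested is made for them only; others in the source may bear on it.

Three compounds have been measured in a functional assay on Umbilical vein for antagonist activity at B1 bradykinin receptor (Homo sapiens), using Schild analysis, with a stated time of 30 min; a higher number here means a more potent compound, by a factor of ten per unit of this negative logarithm, a lower number a less potent compound:

compound 1, `CCN(CC)CCN1CCN(C(=O)COCCN(C)S(=O)(=O)c2c(C)cc(OC)cc2C)CC1`: 7.8
compound 2, `Cc1c(Cl)ccc(S(=O)(=O)N(C)CCOCC(=O)N(C)Cc2ccc(C3=NCCN3)cc2)c1Cl`: 9.1
compound 3, `COc1cc(C)c(S(=O)(=O)N(C)CCOCC(=O)N2CCN(CCN(C)C)CC2)c(C)c1`: 7.4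

Compound 3 is the least potent of the three in this assay; compound 1 is nearest, and compound 2 lies furthest above it. Among the compounds with values here, the only single-point step among the measured compounds is a number 0.40 log units lower from compound 1 to compound 3 (beyond the scatter), a modest fall beyond the scatter. Compound 4, `COc1cc(C)c(S(=O)(=O)N(C)CCOCC(=O)N2CCN(C3CCN(C4CC4)CC3)CC2)c(C)c1`, has not yet been measured. It differs from compound 3 as follows: 1-cyclopropylpiperidin-4-yl in place of 2-(dimethylamino)ethyl on an amine nitrogen in a ring. Within the data shown here, no measured step changes this position by a ring-bearing group, so the one step bearing on it is that from compound 1 to compound 3, which concerns a smaller alteration of the same substituent. On that footing a modest rise in this assay is expected, of size a number 0.40 log units higher from compound 3 to compound 4 (beyond the scatter). Compound 4 is therefore estimated at 7.8, with a range from 7.3 to 8.4.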

Compound 4, negative logarithm of the antagonist equilibrium constant: 8.5
Estimate against measurement, compound 4: 0.70 log units below, outside the stated range (above it).
By their numbers in this assay, from the lowest: compound 3; then compound 1; then compound 4; then compound 2.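

In this assay, moving from an open chain to a group with two rings at this ring nitrogen gives a number 1.10 log units higher from compound 3 to compound 4 (beyond the scatter), a much larger change than the one seen between the two open chains, a number 0.40 log units lower from compound 1 to compound 3 (beyond the scatter). The 1-cyclopropylpiperidin-4-yl group also improves on 2-(diethylamino)ethyl, the better of those chains, with a number 0.70 log units higher from compound 1 to compound 4 (beyond the scatter), so this position accepts far more than a small change at the end of the chain. Nothing available accounts for this rise.

Going by these compounds, it remains open whether the rise belongs to the piperidine ring itself or to the cyclopropyl on its nitrogen, and a 1-methylpiperidin-4-yl or a plain piperidin-4-yl group would help to separate the two. Also open, on these data alone, is whether a pyrrolidine or an azetidine ring carrying the same cyclopropyl would serve equally well here.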